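The compounds below may be only part of what the source reports. "The series", "measured", "known", "first", "only" and "open" are said of these compounds alone.

Measured compounds:
compound 1, `CCOC(=O)CCC(=O)N1CCN(CCCOc2cc3c(Nc4ccc(F)c(Cl)c4)ncnc3cc2OC)CC1`: 61.6%
compound 2, `CCCCCCCCCCCOC(=O)CCC(=O)N1CCN(CCCOc2cc3c(Nc4ccc(F)c(Cl)c4)ncnc3cc2OC)CC1`: 3.9%

Both were tested in a functional assay on A549 cells (Homo sapiens) for cytotoxicity, read by MTT assay, with a stated time of 24 h, tested at 60 uM; on this read-out lower numbers stand for a stronger effect and higher numbers for a weaker effect at the one concentration tested. Of the two numbers, compound 2 gives the lowest, and its nearest neighbour is compound 1 with 61.6%, so compound 2 stands at the strong end of the pair. Compound 3, `CCCCCCCCCCCCCCCCCCCCOC(=O)CCC(=O)N1CCN(CCCOc2cc3c(Nc4ccc(F)c(Cl)c4)ncnc3cc2OC)CC1`, has not yet been measured. It differs from compound 2 by nonyl in place of hydrogen on a saturated chain carbon, ten or more bonds along the chain from an oxygen next to a carbonyl group. For the measured compounds named here, the one measured step that bears on this change is a number 57.7 percentage points lower from compound 1 to compound 2 (beyond the scatter), a large drop. Compound 2 already sits close to the bottom of the scale, so a shift of that size cannot repeat in full. The step expected from compound 2 to compound 3 is therefore a number 2.1 percentage points higher from compound 2 to compound 3 (within the scatter), that is, nothing beyond the scatter. For compound 3 in this assay the estimate is 6%, with a range from 0% to 25%.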

Compound 3, a percentage reported as activity, at one concentration (the size of the read-out at that concentration, not a potency): 86.9%
Beside the measured number, compound 3's estimate is 80.9 percentage points below it; measured number outside the range, above it.
By their numbers in this assay, from the lowest: compound 2; then compound 1; then compound 3.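

In this assay the added nonyl gives a number 83 percentage points higher from compound 2 to compound 3 (beyond the scatter) and this runs against a number 57.7 percentage points lower from compound 1 to compound 2 (beyond the scatter) for the same group at its place two bonds along. Adding chain carbons therefore does not keep strengthening the effect across these compounds, and compound 2 gives the strongest effect of the three, with both of its steps beyond the scatter. Nothing shown here explains this reversal.

Where between the chains of compound 2 and compound 3 the read-out turns remains open, and a compound with a pentadecyl chain would help to locate it. Also open, as far as these compounds go, is whether a carboxylic acid or an amine at the end of the chain would keep the strong effect of compound 2.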